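The source may report more compounds than this note shows. Statements on the series, on what has been measured and on what is new or still open speak of the compounds shown alone.

Measured compounds:
- compound 1, `Oc1ccc(-c2cc(-c3ccccc3)nc(-c3ccccc3Cl)c2)cc1`: 3930 nM
- compound 2, `Oc1cccc(-c2cc(-c3ccccn3)nc(-c3ccccc3Cl)c2)c1`: "not determined" (no result reported)

Within the data shown here, only two compounds have been through an ADME assay on HEK293 cells (Homo sapiens) for cytotoxicity, read by CCK-8 assay and cell counting, with a stated time of 2 days; on this read-out higher numbers stand for weaker inhibition and lower numbers for stronger inhibition. Compound 1 gives 3930 nM in this assay, so it harms the cells only at a fairly high concentration. Among the measured compounds shown here, compound 2 has no number at all: its result in this assay is recorded as "not determined" (no result reported), so there is no value to place it against compound 1, and no step between measured compounds can be computed.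

Compound 3, `Oc1cccc(-c2cc(-c3ccccc3)nc(-c3ccccc3Cl)c2)c1`, is the next candidate for this assay. It is reached from compound 2 by one change: phenyl in place of pyridin-2-yl on an aromatic carbon. For the measured compounds named here, with no step between measured compounds available, the size and direction of this change in this assay cannot be read from data; the expectation is for no step beyond the usual scatter. Going by the values given here, the only anchor is the compound that shares the same two outer aromatic groups as compound 3, namely compound 1, which gives 3930 nM. On that basis compound 3 is expected to give about 4000 nM in this assay, with a plausible range from 1500 nM to 12000 nM, and a real chance that only a limit is reported.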

Compound 3, half-maximal inhibitory concentration: 1760 nM
For compound 3 the middle estimate is 2.3-fold (0.36 log units) above the measured one, and the stated range covers the measured number.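

In this assay, among these compounds, the swap of 4-hydroxyphenyl for 3-hydroxyphenyl on the shared core gives a 2.2-fold lower number from compound 1 to compound 3 (0.35 log units; beyond the scatter) and so provides the first readable step: it is modest but beyond the scatter, and the lower number means stronger inhibition. The change from pyridin-2-yl to phenyl that links compound 2 to compound 3 cannot be read, as compound 2 has no number, so compound 3 shows only what happens when the hydroxyl-bearing ring changes and nothing about the effect of the ring nitrogen. Nothing available accounts for the direction or the size of this step.

The compounds shown leave open what a methoxy group or an amine in place of the hydroxyl would do on the same ring in this assay. They also leave open whether the step between 4-hydroxyphenyl and 3-hydroxyphenyl would hold with pyridin-2-yl in place of phenyl on the core, and what a plain phenyl group would do in place of the 2-chlorophenyl group.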